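The source may report more compounds than this note shows. Statements on the series, on what has been measured and on what is new or still open speak of the compounds shown alone.

Compound 2 `CN(CC(=O)N1CCC[C@H](c2ccccc2)[C@@H]1CN1CCCC1)c1cccc(C(F)(F)F)c1` stands at the lower of the two numbers recorded so far in an assay on HEK293 cells for displacement of a labelled ligand from Urotensin-2 receptor (Homo sapiens); on this read-out higher numbers stand for weaker inhibition and lower numbers for stronger inhibition: compound 2 gives 100 nM, while compound 1 `Cc1ccc(N(C)CC(=O)N2CCC[C@H](c3ccccc3)[C@@H]2CN2CCCC2)cc1C` gives 200 nM. Among the measured compounds shown here, the one measured step, a 2.0-fold lower number from compound 1 to compound 2 (0.30 log units; within the scatter), went with 3-(trifluoromethyl)phenyl in place of 3,4-dimethylphenyl on an amine nitrogen and stayed within the scatter. Compound 3 `COc1cccc(N(C)CC(=O)N2CCC[C@H](c3ccccc3)[C@@H]2CN2CCCC2)c1` has not been measured in this assay. It differs from compound 2 by methoxy in place of trifluoromethyl on an aromatic carbon. For the measured compounds named here, the only measured step that bears on this change, from compound 1 to compound 2, exchanged substituents on the same aromatic ring and moved the number little, so a further exchange on that ring is expected to give a small step in this assay, in either direction or none beyond the scatter. Compound 3 is therefore expected to give 150 nM, within a range from 50 nM to 450 nM. The expected step is a 1.5-fold higher number from compound 2 to compound 3 (0.18 log units; within the scatter).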

Compound 3, inhibition constant: 794 nM
The estimate for compound 3 lay 5.3-fold (0.72 log units) below the measured number; measured number above the stated range.
By their numbers in this assay, from the lowest: compounds 2 and 1 (each within the scatter of the next); then compound 3.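

Methoxy in place of trifluoromethyl on this aromatic carbon went with a 7.9-fold higher number from compound 2 to compound 3 (0.90 log units; beyond the scatter) in this assay and so shows that this position does respond to the group it carries, which the earlier exchange within the scatter had not shown. The same holds against the other neighbour: 3-methoxyphenyl in place of 3,4-dimethylphenyl went with a 4.0-fold higher number from compound 1 to compound 3 (0.60 log units; beyond the scatter) and sets 3-methoxyphenyl apart from the two other aryl groups, which stay within the scatter of each other. Nothing measured here offers a reason for this step, whether in the one hydrogen-bond acceptor that methoxy brings or elsewhere.

The compounds shown leave open where an ethoxy group, a chlorine atom or a nitrile on this carbon would fall in this assay relative to compound 2 and compound 3. They also leave open whether methoxy would behave the same way at another carbon of this ring.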